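Amide nitrogen substituents on the shared core

The source may report more compounds than this note shows. Statements on the series, on what has been measured and on what is new or still open speak of the compounds shown alone.

Measured so far:
compound 1 `CC(C)(C)OC(=O)CNC(=O)c1[nH]cnc1C(=O)Nc1ccc(Cl)c(Cl)c1` gives 49800 nM in a functional assay on HL-60 cells (Homo sapiens), with a stated time of 2 days; on this read-out higher numbers stand for weaker inhibition and lower numbers for stronger inhibition
compound 2 `COC(=O)[C@H](NC(=O)c1[nH]cnc1C(=O)Nc1ccc(Cl)c(Cl)c1)C(C)C` gives 8500 nM in this assay

Among the measured compounds shown here, compound 2 holds the lower of the two numbers; the single measured step is a 5.9-fold lower number from compound 1 to compound 2 (0.77 log units; beyond the scatter). Compound 3 `CCCN(CCC)C(=O)c1[nH]cnc1C(=O)Nc1ccc(Cl)c(Cl)c1` differs from compound 2 by dipropylamino in place of (1-(methoxycarbonyl)-2-methylpropyl)amino on a carbonyl carbon. For the measured compounds named here, only that one step bears on this change, and it varied the substituent while the amide hydrogen remained; no measured step removes it. An expected step of a 1.8-fold higher number from compound 2 to compound 3 (0.25 log units; within the scatter) is therefore set with little confidence. Compound 3 is estimated at 15000 nM in this assay, within 3000 nM to 80000 nM.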

Compound 3, half-maximal inhibitory concentration: 379000 nM
The estimate for compound 3 lay 25-fold (1.40 log units) below the measured number; measured number outside the range, above it.
By their numbers in this assay, from the lowest: compound 2; then compound 1; then compound 3.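

In this assay, dipropylamino on the carbonyl carbon gives a 45-fold higher number from compound 2 to compound 3 (1.65 log units; beyond the scatter) and a 7.6-fold higher number from compound 1 to compound 3 (0.88 log units; beyond the scatter), so the change is far from neutral at this place. Among the compounds shown here, compound 3 is the only compound here without the amide hydrogen and also without an ester, and it holds the highest number of the three, so these two losses cannot be told apart. No measurement on hand explains the rise.

Open, going by these compounds, is whether propylamino, which keeps the amide hydrogen without an ester, stays near compound 2 or moves towards compound 3. Also open, on these data alone, is how a carboxylic acid in place of the ester would read.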